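This account rests on a few compounds, and the source may have more. Where it says the series, first, only, none or still open, it means among the compounds named here.

Within the data shown here, compound 1 `Cc1ccc(CN[C@@H]2C[C@H]3C[C@@H]([C@H]2C)C3(C)C)s1` is one of two compounds measured in an ADME assay on MDCK cells (Canis lupus familiaris) for cytotoxicity, read by microscopy, with a stated time of 48 h (on this read-out lower numbers stand for higher toxicity in this test and higher numbers for lower toxicity in this test), where compound 1 gives 780 nM. Among the measured compounds shown here, its only companion is compound 2 `C[C@H]1[C@H](NCc2sccc2C2CCCC2)C[C@H]2C[C@@H]1C2(C)C`, which in this assay gives 12500 nM; the gap between the two is beyond the scatter, and compound 1 stands with the lower of the two numbers. Compound 3 `Cc1csc(CN[C@@H]2C[C@H]3C[C@@H]([C@H]2C)C3(C)C)c1` has not been measured in this assay. It is an isomer of compound 1 (4-methylthiophen-2-yl in place of 5-methylthiophen-2-yl on a saturated chain carbon bound to an amine nitrogen), so the two share every atom and differ only in where the methyl sits on the thiophene. For the measured compounds named here, no measured pair shows what such a rearrangement does here, and with only two compounds on record there is no pattern to lean on. The step of a 1.3-fold higher number from compound 1 to compound 3 (0.11 log units; within the scatter) that this account expects is small, in no firm direction, and within the usual scatter. Compound 3 is therefore estimated at 1000 nM, with a range from 300 nM to 3200 nM.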

Compound 3, minimum cytotoxic concentration: 12500 nM
Beside the measured number, compound 3's estimate is 13-fold (1.10 log units) below it; the measured number lies above the stated range.
By their numbers in this assay, from the lowest: compound 1; then compounds 2 and 3 (each within the scatter of the next).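

Shifting the methyl on the thiophene, with every atom kept, is enough to change the read-out in this assay: 4-methylthiophen-2-yl in place of 5-methylthiophen-2-yl gives a 16-fold higher number from compound 1 to compound 3 (1.20 log units; beyond the scatter). Among these compounds, the earlier compounds formed no pair differing in one place, so this is the first sign that the read-out responds to where the methyl sits on this group, not only to which atoms are present. Nothing on record accounts for the size of this step.

On these data alone, this rests on a single pair on the shared core, so it remains open whether the same shift would matter on another core. As far as these compounds go, it is also open how the read-out would respond to an ethyl group in place of the methyl, or to a furan in place of the thiophene.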